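The compounds below may be only part of what the source reports. "The series", "measured", "known", "first", "only" and "open" are said of these compounds alone.

In a functional assay on MKN-45 cells (Homo sapiens) for cytotoxicity (on this read-out lower numbers stand for stronger inhibition and higher numbers for weaker inhibition), two compounds with a shared core have been measured so far: compound 1 (`COc1ccc(S(=O)(=O)N2CCc3cccc(NC(=O)C(C)(C)C)c32)cc1`) gives 289 nM and compound 2 (`COc1ccc(S(=O)(=O)N2CCc3cccc(NC(=O)c4ccccc4)c32)cc1`) gives 250 nM and so the two stand within the scatter of each other. Compound 3 (`COc1ccc(C(=O)Nc2cccc3c2N(S(=O)(=O)c2ccc(OC)cc2)CC3)cc1`) departs from compound 2 by one change (methoxy in place of hydrogen on an aromatic carbon), with methoxy in place of hydrogen on an aromatic carbon, para to a large group. For the measured compounds named here, only one measured step bears on it (a 1.2-fold lower number from compound 1 to compound 2 (0.06 log units; within the scatter)), phenyl in place of tert-butyl on a carbonyl carbon, and that step stays within the scatter. Going by the values given here, no measured compound carries a substituent on this ring, so the evidence is thin. In this assay no step beyond the scatter is therefore expected, and the estimated step (a 1.3-fold lower number from compound 2 to compound 3 (0.10 log units; within the scatter)) has no firm direction. For compound 3 the estimate is 200 nM with 60 nM to 600 nM as its expected range.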

Compound 3, half-maximal inhibitory concentration: 1600 nM
Estimate against measurement, compound 3: 8.0-fold (0.90 log units) below; the measured number lies above the stated range.
By their numbers in this assay, from the lowest: compounds 2 and 1 (each within the scatter of the next); then compound 3.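

In this assay, substitution on the benzoyl ring proves to matter: methoxy in place of hydrogen on an aromatic carbon, para to a large group, gives a 6.4-fold higher number from compound 2 to compound 3 (0.81 log units; beyond the scatter) and so weakens inhibition. The earlier exchange on the carbonyl carbon stayed within the scatter (a 1.2-fold lower number from compound 1 to compound 2 (0.06 log units; within the scatter)), whereas 4-methoxyphenyl in place of tert-butyl gives a 5.5-fold higher number from compound 1 to compound 3 (0.74 log units; beyond the scatter) and shows that this end of the molecule does respond to change, here towards weaker inhibition. Nothing available accounts for the loss seen with the methoxy group.

The compounds shown leave open whether the loss belongs to methoxy itself, since a hydroxyl, a fluorine or an amine on the same carbon could give a different result. They also leave open whether an ethoxy group, a longer chain at that carbon, would weaken inhibition further.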